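Pyridin-3-yl in place of the halogenated benzyl ring

The compounds below may be only part of what the source reports. "The series", "measured", "known", "first", "only" and "open" are said of these compounds alone.

The series shares one core, varied only in the aryl group on a saturated chain carbon bound to an amine nitrogen in a ring. In an assay on FRT cells for positive allosteric modulation of Cystic fibrosis transmembrane conductance regulator variant N1303K (Homo sapiens), in the presence of a further agent that is not named here (on this read-out higher numbers stand for an effect only at larger amounts of compound and lower numbers for an effect already at smaller amounts), compound 1 `COc1ccc2[nH]c3c(c2c1)CCNC31CCN(Cc2ccc([N+](=O)[O-])cc2F)CC1` gives 5900 nM, compound 2 `COc1ccc2[nH]c3c(c2c1)CCNC31CCN(Cc2cc(Cl)ccc2[N+](=O)[O-])CC1` gives 7100 nM, and compound 3 `COc1ccc2[nH]c3c(c2c1)CCNC31CCN(Cc2c(F)ccc(Cl)c2F)CC1` gives 1500 nM. Compound 3 stands lowest of the three, with steps to both others beyond the scatter: a 3.9-fold lower number from compound 1 to compound 3 (0.59 log units; beyond the scatter) and a 4.7-fold lower number from compound 2 to compound 3 (0.68 log units; beyond the scatter). Between compound 1 and compound 2 the step is within the scatter: a 1.2-fold higher number from compound 1 to compound 2 (0.08 log units; within the scatter).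

Compound 4 `COc1ccc2[nH]c3c(c2c1)CCNC31CCN(Cc2cccnc2)CC1` is not yet measured. Its change from compound 3: pyridin-3-yl in place of 3-chloro-2,6-difluorophenyl on a saturated chain carbon bound to an amine nitrogen in a ring. Within the data shown here, no measured step removes the 3-chloro-2,6-difluorophenyl group altogether or introduces a pyridin-3-yl, so the bearing steps are only indirect. They show that the 3-chloro-2,6-difluorophenyl gives a lower number than either nitro-bearing phenyl, so its loss is expected to carry the number back upward, roughly to where compound 1 and compound 2 stand, with wide uncertainty.

Compound 4 is therefore expected to give about 6000 nM in this assay, between 2500 nM and 15000 nM, which means an expected step of a 4.0-fold higher number from compound 3 to compound 4 (0.60 log units; beyond the scatter).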

Compound 4, half-maximal effective concentration: 17000 nM
Compound 4: middle estimate off by 2.8-fold (0.45 log units), on the low side, and the stated range ends below it.
By their numbers in this assay, from the lowest: compound 3; then compounds 1 and 2 (each within the scatter of the next); then compound 4.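

In this assay the pyridin-3-yl group sits at the top of the series, with an 11-fold higher number from compound 3 to compound 4 (1.05 log units; beyond the scatter), a 2.4-fold higher number from compound 2 to compound 4 (0.38 log units; beyond the scatter) and a 2.9-fold higher number from compound 1 to compound 4 (0.46 log units; beyond the scatter). The position therefore has a wider span than the earlier compounds showed: compounds 1 and 2 do not mark the upper end of the series, and all three substituted phenyl groups give lower numbers than pyridin-3-yl, with no compound shown going against this order. No measurement shown here accounts for the size of these steps.

Going by these compounds, this change replaces a ring carbon with nitrogen and removes both the fluorines and the chlorine in a single step, so the share of each remains open. An unsubstituted phenyl group would separate the two, and single-halogen phenyl groups, such as 3-chlorophenyl or 2,6-difluorophenyl, would show whether the chlorine or the fluorines carry the lower number of compound 3 1500 nM.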